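This account rests on a few compounds, and the source may have more. Where it says the series, first, only, none or still open, it means among the compounds named here.

Compound 3 `N#CC1=C(N)Oc2c(N)cc3nc4ccccc4nc3c2C12C(=O)N(Cc1cnnn1-c1ccccc1Cl)c1ccccc12` is the starting point of this step. In a functional assay on HCT-116 cells (Homo sapiens) for antiproliferative activity, read by MTT assay, with a stated time of 48 h (a lower number here means a stronger inhibitor, a higher number a weaker inhibitor), compound 3 gives only an assay limit, > 50000 nM, not a number. Two related compounds share that standing. Compound 1 `COc1ccccc1-n1nncc1CN1C(=O)C2(C(C#N)=C(N)Oc3c2c2nc4ccccc4nc2c2ccccc32)c2ccccc21` gives a limit of > 50000 nM in this assay. Compound 2 `CCOc1ccccc1-n1nncc1CN1C(=O)C2(C(C#N)=C(N)Oc3c2c2nc4ccccc4nc2c2ccccc32)c2ccccc21` likewise gives a limit of > 50000 nM. In fact (the limit of > 50000 nM in this assay, at which 3 of the 3 values shown sit), so every value here is a limit. Within the data shown here, the one step between measured compounds, a step that the two limits leave unreadable from compound 1 to compound 2, therefore cannot be read. Compound 4 `N#CC1=C(N)Oc2c(N)cc3nc4ccccc4nc3c2C12C(=O)N(Cc1cnnn1-c1ccc([N+](=O)[O-])cc1[N+](=O)[O-])c1ccccc12` differs from compound 3 by 2,4-dinitrophenyl in place of 2-chlorophenyl on an aromatic nitrogen. Among the measured compounds shown here, no measured step bears on this change, so no shift beyond the scatter can be expected in either direction. The expected step of a number no higher from compound 3 to compound 4 (the limit leaves the size open) reflects that. For compound 4 the estimate is therefore 50000 nM, expected to fall between 10000 nM and 200000 nM, most probably again only a limit.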

Compound 4, half-maximal inhibitory concentration: 23900 nM
Compound 4: the middle estimate sits 2.1-fold (0.32 log units) above what was measured; the measured number falls inside the stated range.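

In this assay, the group on the aromatic nitrogen proves able to move the result: 2,4-dinitrophenyl in place of 2-chlorophenyl gives an at least 2.0-fold lower number from compound 3 to compound 4 (0.32 log units; beyond the scatter). Compound 4 is the only compound shown with a readable number, and the others stay at the assay limit: the limit of > 50000 nM in this assay, at which 3 of the 4 values shown sit. From the compounds shown here alone, compound 3 has only a limit, so the full size of this step remains unknown. Going by these compounds, whether a single nitro group would give the same step remains open, as does the outcome with an amine or a carboxylic acid on that phenyl ring.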